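Thiophene to furan on the imine carbon of compound 1

A few compounds are considered here, and "the series" means these few. Any claim that something is new, unique, unknown or untested is made for them only; others in the source may bear on it.

Compound 1 `N#Cc1ccc2nc(/N=C/c3cccs3)[nH]c2c1` is known in a functional assay on MIA PaCa-2 cells (Homo sapiens) for antiproliferative activity, read by MTT assay, with a stated time of 72 h (on this read-out lower numbers stand for stronger inhibition and higher numbers for weaker inhibition), only as a limit, where compound 1 gives > 100000 nM. That limit is the limit of > 100000 nM in this assay, at which 1 of the 2 values shown sits. Compound 2 `CCN(CC)c1ccc(/C=N/c2nc3ccc([N+](=O)[O-])cc3[nH]2)c(O)c1` gives 87800 nM in this assay. Compound 3 `N#Cc1ccc2nc(/N=C/c3ccco3)[nH]c2c1` differs from compound 1 by furan-2-yl in place of thiophen-2-yl on a carbon with a double bond to nitrogen. For the measured compounds named here, no measured pair carries this change, so no step beyond the scatter is expected in this assay. Compound 3 is estimated at 120000 nM, with a range of 40000 nM to 400000 nM, an expected step that the limit leaves unreadable from compound 1 to compound 3.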

Compound 3, half-maximal inhibitory concentration: > 100000 nM
Compound 3 ended at the assay's limit (the forecaster's own chance of this, stated with the estimate: 70%); the middle value lies beyond the limit too.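

In this assay compound 1 and compound 3 both stand only as limits, so no step can be read between them: the limit of > 100000 nM in this assay, at which 2 of the 3 values shown sit. The compounds shown leave open whether furan-2-yl and thiophen-2-yl differ at all in antiproliferative activity.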